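A Chloro Change and Tolerance in Human Cells

A few compounds are considered here, and "the series" means these few. Any claim that something is new, unique, unknown or untested is made for them only; others in the source may bear on it.

Compound 1 `C1=C(/C=C/c2ccccn2)COc2ccccc21` and compound 2 `Clc1ccc2c(c1)C=C(/C=C/c1ccccn1)CO2` share one core and differ by chloro in place of hydrogen on an aromatic carbon. Both were tested in an ADME assay on HeLa cells (Homo sapiens) for cytotoxicity, read by XTT assay, with a stated time of 3 days; a higher number here means that more compound is tolerated, a lower number that less compound is tolerated. Compound 1 gives > 50000 nM, which is a limit of the assay rather than a number. Compound 2 gives > 50000 nM, again a limit. The step that the two limits leave unreadable from compound 1 to compound 2 cannot be read, as both compounds sit at the limit of > 50000 nM in this assay, at which 2 of the 3 values shown sit. Compound 3 `O=c1c(/C=C/c2ccccn2)coc2ccccc12` has a different core; how the two cores differ is not broken down here. In this assay compound 3 gives > 200000 nM, also a limit, namely (the limit of > 200000 nM in this assay, at which 1 of the 3 values shown sits). Compound 4 `O=c1c(/C=C/c2ccccn2)coc2ccc(Cl)cc12` differs from compound 3 by chloro in place of hydrogen on an aromatic carbon, the same change as from compound 1 to compound 2. That earlier step left both partners at a limit. On that ground the expected step is a number no higher from compound 3 to compound 4 (the limit leaves the size open). The estimate for compound 4 is 200000 nM, expected between 100000 nM and 500000 nM.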

Compound 4, half-maximal cytotoxic concentration: > 50000 nM
Compound 4 was reported as a limit; the forecaster's own chance of this, stated with the estimate: 75%; the middle value lies beyond the limit too.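

Compound 3 and compound 4 both sit at limits of this assay, not at numbers, so the step between them cannot be read. The compounds shown leave open whether chloro in place of hydrogen changes tolerance at all, on either core.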